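The source may report more compounds than this note shows. Statements on the series, on what has been measured and on what is new or still open speak of the compounds shown alone.

Measured so far:
compound 1 `CNc1nc(NCc2ccc(NC(=O)c3ccncc3)cc2)c2ccccc2n1`: in a functional assay on HCT-116 cells (Homo sapiens) for inhibition, read by luminescence and resazurin assay, with a stated time of 3 days (on this read-out higher numbers stand for weaker inhibition and lower numbers for stronger inhibition), compound 1 gives > 20000 nM, which is a limit of the assay and not a number.
compound 2 `CN(C)c1nc(NCc2ccc(NC(=O)c3ccncc3)cc2)c2ccccc2n1`: compound 2 gives 15000 nM.
compound 3 `CNc1nc(NCc2ccc(C(=O)Nc3ccc(F)cc3)cc2)c2ccccc2n1`: compound 3 gives 2900 nM.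

Compound 1 thus stands at the limit of > 20000 nM in this assay, at which 1 of the 3 values shown sits, with no number of its own. The unmeasured compound 4 `CNc1nc(NCc2ccc(NS(=O)(=O)c3ccc(C)cc3)cc2)c2ccccc2n1` differs from compound 1 by (4-methylphenyl)sulfonyl in place of (pyridin-4-yl)carbonyl on a nitrogen on an aromatic ring. Of the measured steps, an at least 1.3-fold lower number from compound 1 to compound 2 (0.12 log units; that floor lies within the scatter) touches another part of the shared core and is small, whereas an at least 6.8-fold lower number from compound 1 to compound 3 (0.83 log units; beyond the scatter) reworks the same end of the molecule and goes clearly beyond the scatter. A step of that kind, toward a lower number, seems plausible here, though the starting point is only a limit. Compound 4 is expected at 8000 nM, within 2000 nM to 30000 nM. The estimated step is an at least 2.5-fold lower number from compound 1 to compound 4 (0.39 log units; beyond the scatter).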

Compound 4, half-maximal inhibitory concentration: 5800 nM
Estimate against measurement, compound 4: 1.4-fold (0.14 log units) above, and the stated range covers the measured number.
By their numbers in this assay, from the lowest: compounds 3 and 4 (each within the scatter of the next); then compound 2. At a limit, above all of these: compound 1.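

On a nitrogen on an aromatic ring, (4-methylphenyl)sulfonyl in place of (pyridin-4-yl)carbonyl gives an at least 3.4-fold lower number from compound 1 to compound 4 (0.53 log units; beyond the scatter) in this assay, so a change at this position that keeps the nitrogen in place already moves the read-out beyond the scatter. Compound 1 gives > 20000 nM, which is a limit and not a number. The true size of the step stays unknown because only a floor can be read: the limit of > 20000 nM in this assay, at which 1 of the 4 values shown sits.

The sulfonyl and the ring changed together, so their shares stay unseparated. A 4-methylbenzoyl group or a (pyridin-4-yl)sulfonyl group on the same nitrogen would divide them.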